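Notes on an acetyl exchange in the series

The source may hold more compounds than are shown below. What is called first, only, known or untested is meant among the compounds shown, and "the series" means these compounds.

Measured in a functional assay on TK-10 cells (Homo sapiens) for inhibition, read by sulforhodamine B assay, with a stated time of 48 h, tested at 10 uM; on this read-out lower numbers stand for less inhibition of growth and higher numbers for more inhibition of growth at the one concentration tested:
- compound 1 `C/C(=N/O)c1ccc(NC(=O)Cn2nc(C(F)(F)F)nc2N)cc1`: 14.3%
- compound 2 `COc1cc(-c2nc3sc(-c4ccccc4)cn3n2)cc(OC)c1OC`: 6%

Compound 1 and compound 2 lie within the scatter of each other, so compound 1 holds no distinct rank. Compound 3 `CC(=O)c1ccc(NC(=O)Cn2nc(C(F)(F)F)nc2N)cc1`, not yet measured, differs from compound 1: a group of 3 heavy atoms (2 carbon, 1 oxygen; no ring) in place of a group of 4 heavy atoms (2 carbon, 1 nitrogen, 1 oxygen; no ring), on an aromatic carbon. Acetyl stands on an aromatic carbon of a six-membered aromatic ring of carbon only, para to a large group. The starting point is compound 1 at 14.3%. Among the measured compounds shown here, no measured step covers this exchange, so no shift beyond the scatter is expected from compound 1. The estimated change is a number 2.3 percentage points lower from compound 1 to compound 3 (within the scatter). In this assay, the expected value for compound 3 is 12%, with an estimated range of 0% to 25%.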

Compound 3, percent growth inhibition at one concentration: 5.17%
For compound 3 the middle estimate is 6.8 percentage points above the measured one, and the stated range covers the measured number.
By their numbers in this assay, from the lowest: compounds 3, 2 and 1 (each within the scatter of the next).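

Among the compounds shown here, the exchange gives the first measured step at this position, on an aromatic carbon para to a large group. In this assay, acetyl in place of the group of compound 1 gives a step that stays inside the usual scatter (a number 9.1 percentage points lower from compound 1 to compound 3 (within the scatter)), so the two groups cannot be told apart on this read-out. No measurement at hand bears on the reason for this result.

As far as these compounds go, whether an amine, a carboxylic acid or a longer chain at this position would give a step beyond the scatter remains open.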